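Aryl swap on the shared core: from nitrophenyl to dichlorophenyl

The source may report more compounds than this note shows. Statements on the series, on what has been measured and on what is new or still open speak of the compounds shown alone.

The series rests on a shared core carrying a trifluoromethyl-substituted benzylidene hydrazine. Compound 1 `O=[N+]([O-])c1ccc(-c2csc(N/N=C/c3ccc(C(F)(F)F)cc3)n2)cc1` was tested in a functional assay on K562 cells (Homo sapiens) for inhibition, read by MTT assay, with a stated time of 72 h (a lower number here means a stronger inhibitor, a higher number a weaker inhibitor), and gave 16900 nM. Compound 2 `O=[N+]([O-])c1cccc(-c2csc(N/N=C/c3ccc(C(F)(F)F)cc3)n2)c1` carries a 3-nitrophenyl in place of the 4-nitrophenyl of compound 1, and in the same assay compound 2 gave 10200 nM. Going by the values given here, the step of a 1.7-fold lower number from compound 1 to compound 2 (0.22 log units; within the scatter) is the only measured comparison so far, and it lies within the scatter, so compound 2 cannot be set apart from compound 1 on these numbers.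

Compound 3 `FC(F)(F)c1ccc(/C=N/Nc2nc(-c3ccc(Cl)cc3Cl)cs2)cc1` is the next compound and differs from compound 2 by 2,4-dichlorophenyl in place of 3-nitrophenyl on an aromatic carbon. Among the compounds with values here, no measured step bears directly on this exchange of a nitrophenyl for a dichlorophenyl; the only step recorded, a 1.7-fold lower number from compound 1 to compound 2 (0.22 log units; within the scatter), concerns a move of the nitro group within the same ring and was itself within the scatter. On this basis the account expects no step beyond the scatter, so a 1.1-fold lower number from compound 2 to compound 3 (0.05 log units; within the scatter) is the estimated change. Compound 3 is therefore estimated at 9000 nM in this assay, with a range from 3000 nM to 30000 nM.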

Compound 3, half-maximal inhibitory concentration: 5480 nM
For compound 3 the middle estimate is 1.6-fold (0.22 log units) above the measured one, within the range that was stated.
By their numbers in this assay, from the lowest: compounds 3, 2 and 1 (each within the scatter of the next, the first and the last beyond it).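

Going by these compounds alone, compound 3 gives the first exchange at this position that separates two compounds: on an aromatic carbon of the five-membered aromatic ring, next to the ring nitrogen, 2,4-dichlorophenyl in place of 4-nitrophenyl gives a 3.1-fold lower number from compound 1 to compound 3 (0.49 log units; beyond the scatter), a modest step. The same group in place of 3-nitrophenyl gives a 1.9-fold lower number from compound 2 to compound 3 (0.27 log units; within the scatter), so the separation holds only against 4-nitrophenyl, while the change of ring substituents from nitro to two chlorines shows that a nitro group on this ring is not required for a number in the range of compound 2. Nothing measured among the data at hand explains either step.

The compounds shown leave open what each chlorine contributes on its own, and how a phenyl ring carrying an amine or a carboxylic acid would read at this position. They also leave open how far these steps depend on the trifluoromethyl-substituted benzylidene hydrazine, which stays the same in all three compounds, so the reading of this position rests on that one setting alone.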